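The compounds below may be only part of what the source reports. "The series", "measured", "known", "first", "only" and "open" are said of these compounds alone.

Compound 1 `Nc1scc(CN2CCN(c3cccc(Cl)c3Cl)CC2)c1C(=O)c1ccc(Cl)cc1`: -57%
Compound 2 `Nc1scc(CN2CCN(c3ccc([N+](=O)[O-])cc3)CC2)c1C(=O)c1ccc(Cl)cc1`: -8.3%
Compound 3 `Nc1scc(CN2CCN(c3cccc(F)c3)CC2)c1C(=O)c1ccc(Cl)cc1`: -86%

In a functional assay on CHO cells with adenosine receptor A1 (Homo sapiens) as the target, read by cAMP accumulation and immunoassay, with a stated time of 6 min, tested at 1 uM (on this read-out higher numbers stand for a weaker effect at the one concentration tested and lower numbers for a stronger effect), compound 3 gives -86%, the lowest of the three numbers; it is reached by a number 29 percentage points lower from compound 1 to compound 3 (beyond the scatter) and by a number 77.7 percentage points lower from compound 2 to compound 3 (beyond the scatter), both beyond the scatter. Compound 4 `Nc1scc(CN2CCN(c3cccc(Cl)c3)CC2)c1C(=O)c1ccc(Cl)cc1` is the next step, a single change: chloro in place of fluoro on an aromatic carbon. Among the measured compounds shown here, no measured step swaps one halogen for another at the same place; the two steps above exchange whole phenyl patterns and are large. Compound 1, carrying chlorine on its phenyl ring, is the nearer neighbour, at a number 29 percentage points lower from compound 1 to compound 3 (beyond the scatter), so for compound 4 a small shift is expected, a number 8 percentage points higher from compound 3 to compound 4 (within the scatter), not clearly beyond the scatter. For compound 4 in this assay the estimate is -78%, within -95% to -55%.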

Compound 4, a percentage reported as activity, at one concentration (the size of the read-out at that concentration, not a potency): -59%
Compound 4: the middle estimate sits 19 percentage points below what was measured; the range from low to high includes it.
By their numbers in this assay, from the lowest: compound 3; then compounds 4 and 1 (each within the scatter of the next); then compound 2.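

In this assay, swapping one halogen for another at this place on the ring is not a neutral exchange: chloro in place of fluoro gives a number 27 percentage points higher from compound 3 to compound 4 (beyond the scatter). Hydrogen in place of one chloro of the 2,3-dichlorophenyl pattern gives a number 2 percentage points lower from compound 1 to compound 4 (within the scatter), so those two compounds cannot be told apart, while 3-chlorophenyl in place of 4-nitrophenyl gives a number 50.7 percentage points lower from compound 2 to compound 4 (beyond the scatter). Nothing available explains the gap between the two halogens. As far as these compounds go, what bromo, a methoxy group or an amine would give at this place remains open.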